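The source may report more compounds than this note shows. Statements on the series, on what has been measured and on what is new or still open speak of the compounds shown alone.

Measured so far:
compound 1, `CC1CC(=O)N(CC(=O)N2CCN(c3ccc(Cl)cc3)CC2)C1=O`: 100 mg/kg
compound 2, `CC1CC(=O)N(CC(=O)N2CCN(c3cccc(Cl)c3)CC2)C1=O`: 100 mg/kg
compound 3, `Cc1cccc(N2CCN(C(=O)CN3C(=O)CC(C)C3=O)CC2)c1`: 300 mg/kg

All three share one core and differ only in the aromatic group on the amine nitrogen in a ring. In a functional assay on the whole organism (strain CD1) with Mus musculus as the target, in the maximal electroshock model, with a stated time of 0.5 h (a lower number here means that less compound is needed, a higher number that more compound is needed for the effect), compound 3 has the highest number of the three: the step of a 3.0-fold higher number from compound 1 to compound 3 (0.48 log units; beyond the scatter) and the step of a 3.0-fold higher number from compound 2 to compound 3 (0.48 log units; beyond the scatter) both go beyond the scatter, so compound 3 needs more compound than either of the others, while compounds 1 and 2 cannot be told apart, as no change at the digits printed from compound 1 to compound 2 (within the scatter) shows.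

Compound 4, `CC1CC(=O)N(CC(=O)N2CCN(c3ccc(F)cc3)CC2)C1=O`, has not yet been tested. The change from compound 3 is 4-fluorophenyl in place of 3-methylphenyl on an amine nitrogen in a ring. Among the measured compounds shown here, two measured steps bear on it. The move from chloro to methyl on the aromatic carbon raised the number, a 3.0-fold higher number from compound 2 to compound 3 (0.48 log units; beyond the scatter); going back toward a halogen-bearing phenyl should reverse that. Moving a chloro between the 3- and 4-position changed nothing, no change at the digits printed from compound 1 to compound 2 (within the scatter), so the position of the fluoro is not expected to matter much either.

In this assay compound 4 is therefore expected to give about 100 mg/kg, with a range from 50 mg/kg to 300 mg/kg. That estimate means an expected 3.0-fold lower number from compound 3 to compound 4 (0.48 log units; beyond the scatter).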

Compound 4, minimum effective dose: 300 mg/kg
Beside the measured number, compound 4's estimate is 3.0-fold (0.48 log units) below it, and the stated range covers the measured number.
By their numbers in this assay, from the lowest: compounds 1 and 2 (each within the scatter of the next); then compounds 3 and 4 (each within the scatter of the next).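

The result separates fluoro from chloro at the same place on the phenyl ring: in this assay, fluoro in place of chloro gives a 3.0-fold higher number from compound 1 to compound 4 (0.48 log units; beyond the scatter), so a halogen on this ring does not by itself bring the lower number. The 4-fluorophenyl group also fails to match the 3-chlorophenyl group, with a 3.0-fold higher number from compound 2 to compound 4 (0.48 log units; beyond the scatter), yet it cannot be told apart from the 3-methylphenyl group, with no change at the digits printed from compound 3 to compound 4 (within the scatter); among these four compounds, only the two chlorophenyl compounds, compound 1 and compound 2, sit at the lower number. No available data explain why chloro and fluoro part here.

As far as these compounds go, it remains open whether the lower number is particular to chloro or would also appear with bromo, trifluoromethyl or methoxy at this place on the ring. Only chloro appears at both the 3- and 4-positions in the compounds shown, so 3-fluorophenyl and 4-methylphenyl would show whether position matters for those groups as little as it does for chloro.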